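Benzyl ring substituent change on the thiourea series

The source may report more compounds than this note shows. Statements on the series, on what has been measured and on what is new or still open speak of the compounds shown alone.

In a functional assay on SW-620 cells (Homo sapiens) for inhibition, read by MTT assay, with a stated time of 48 h (a higher number here means a weaker inhibitor, a lower number a stronger inhibitor), compound 1 `Cc1ccc(NC(=S)NC(=O)c2ccc(OCc3ccccc3)cc2)cc1-c1nc2ccccc2[nH]1` gives 67100 nM. Compound 3 `Cc1ccc(NC(=S)NC(=O)c2ccc(OCc3cccc(C(F)(F)F)c3)cc2)cc1-c1nc2ccccc2[nH]1` gives 15400 nM in this assay, the lowest of the two numbers obtained, and the nearest number is separated from it by a 4.4-fold lower number from compound 1 to compound 3 (0.64 log units; beyond the scatter). For compound 2 `Cc1ccc(NC(=S)NC(=O)c2ccc(OCc3cccc(Cl)c3)cc2)cc1-c1nc2ccccc2[nH]1` this assay returns only a limit, > 100000 nM. The remaining steps read an at least 1.4-fold higher number from compound 1 to compound 2 (0.17 log units; that floor lies within the scatter) and an at least 6.4-fold lower number from compound 2 to compound 3 (0.81 log units; beyond the scatter), the second resting on that limit (the limit of > 100000 nM in this assay, at which 1 of the 3 values shown sits).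

Compound 4 `Cc1ccc(NC(=S)NC(=O)c2ccc(OCc3ccccc3F)cc2)cc1-c1nc2ccccc2[nH]1` differs from compound 3 by 2-fluorophenyl in place of 3-(trifluoromethyl)phenyl on a saturated chain carbon bound to an oxygen on an aromatic ring. The step that bears directly on this is the trifluoromethyl-for-hydrogen step, a 4.4-fold lower number from compound 1 to compound 3 (0.64 log units; beyond the scatter), which the removal of trifluoromethyl would be expected to undo, so a higher number is expected. Going by the values given here, for the entering fluorine no measured step exists; the only ring-halogen step, an at least 1.4-fold higher number from compound 1 to compound 2 (0.17 log units; that floor lies within the scatter), lay at a floor within the scatter. The expected step is therefore a 3.2-fold higher number from compound 3 to compound 4 (0.51 log units; beyond the scatter), back toward the number of compound 1. Compound 4 is estimated at 50000 nM, with a range from 15000 nM to 150000 nM.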

Compound 4, half-maximal inhibitory concentration: 6440 nM
Compound 4: the middle estimate sits 7.8-fold (0.89 log units) above what was measured; measured number outside the range, below it.
By their numbers in this assay, from the lowest: compound 4; then compound 3; then compound 1. At a limit, above all of these: compound 2.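

In this assay, fluoro in place of hydrogen, as 2-fluorophenyl, gives a 10-fold lower number from compound 1 to compound 4 (1.02 log units; beyond the scatter), so a lower number at this position does not depend on trifluoromethyl. Trifluoromethyl is also not needed to hold the gain: 2-fluorophenyl, the group with fewer heavy atoms, in place of 3-(trifluoromethyl)phenyl gives a 2.4-fold lower number from compound 3 to compound 4 (0.38 log units; beyond the scatter). Against 3-chlorophenyl the change gives an at least 15-fold lower number from compound 2 to compound 4 (1.19 log units; beyond the scatter), but this step is only a floor, set by the limit for compound 2: the limit of > 100000 nM in this assay, at which 1 of the 4 values shown sits.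

The compounds shown do not separate the identity of the substituent from its place on the ring, so 3-fluorophenyl and 2-chlorophenyl would be the informative comparisons in this assay. Also open, on these data alone, is how an amine or a methoxy group on this ring would read against compound 4.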